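The source may hold more compounds than are shown below. What is called first, only, known or untested is meant among the compounds shown, and "the series" means these compounds.

Measured in a functional assay on HeLa cells (Homo sapiens) for antiproliferative activity, read by sulforhodamine B assay, with a stated time of 72 h; on this read-out lower numbers stand for stronger inhibition and higher numbers for weaker inhibition:
compound 1 `O=C1CS/C(=N/Nc2nncc3ccccc23)N1c1ccccc1` at 56 nM
compound 2 `C(=C/c1ccccc1)\C(=N\Nc1nncc2ccccc12)c1ccccc1` at 1.4 nM

Compound 2 holds the lower of the two numbers, and compound 1 sits higher by a gap beyond the usual scatter. For the measured compounds named here, no measured pair differs in one place only, so no single change has yet been seen at work.

Compound 3 `Clc1ccc(C(/C=C/c2ccccc2)=N\Nc2nncc3ccccc23)cc1` is the next to be read against compound 2. The change is chloro in place of hydrogen on an aromatic carbon and it reads in words as chloro in place of hydrogen on an aromatic carbon, or phenyl to 4-chlorophenyl, para to a large group. Going by the values given here, the expectation in this assay rests only on compound 2 at 1.4 nM and on this one change, with no measured precedent for it. No step beyond the scatter is expected, and any drift is expected to be slight and toward a higher number. The estimated step of a 1.4-fold higher number from compound 2 to compound 3 (0.15 log units; within the scatter) is expected to stay within the scatter. For compound 3 the estimated value is 2 nM with an expected range of 0.6 nM to 8 nM.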

Compound 3, half-maximal inhibitory concentration: 3.3 nM
The estimate for compound 3 lay 1.7-fold (0.22 log units) below the measured number; the measured number falls inside the stated range.
By their numbers in this assay, from the lowest: compound 2; then compound 3; then compound 1.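

In this assay, for the compounds shown here, chloro in place of hydrogen on an aromatic carbon, para to a large group, gives a 2.4-fold higher number from compound 2 to compound 3 (0.37 log units; beyond the scatter), the first single change that can be read. Phenyl to 4-chlorophenyl is therefore not neutral at this position: one added chlorine atom shifts the number beyond the scatter, although the step is only modest and compound 3 still gives 3.3 nM. No measurement at hand explains the direction or the size of this step.

With only one substituent shown at this position, it remains open whether the step belongs to chloro itself or would also appear with fluoro, methyl, methoxy, an amine or a carboxylic acid in its place. On these data alone, compound 1 differs from compound 2 and compound 3 in more than one place, so its number cannot be tied to any single change, and the effect of chloro on the core of compound 1 also remains open.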